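The source may hold more compounds than are shown below. What is called first, only, known or untested is meant among the compounds shown, and "the series" means these compounds.

Measured in a functional assay on A549 cells (Homo sapiens) for antiproliferative activity, read by MTT assay, with a stated time of 72 h; on this read-out higher numbers stand for weaker inhibition and lower numbers for stronger inhibition:
- Compound 1 `COc1ccc(-c2noc(CCCCCCC(=O)NO)n2)cc1`: 13500 nM.
- Compound 2 `O=C(CCCCCCc1nc(-c2ccccc2)no1)C(F)(F)F`: 7680 nM.
- Compound 3 `Cc1ccc(-c2noc(CCCCCCC(=O)C(F)(F)F)n2)cc1`: > 100000 nM, a limit and not a number.

Compound 3 has only a limit, (the limit of > 100000 nM in this assay, at which 1 of the 3 values shown sits). Compound 4 `COc1ccc(-c2noc(CCCCCCC(=O)C(F)(F)F)n2)cc1` carries 4-methoxyphenyl in place of 4-methylphenyl: methoxy in place of methyl on an aromatic carbon. The change lies on an aromatic carbon, para to a large group. Within the data shown here, the one measured step at this place is an at least 13-fold higher number from compound 2 to compound 3 (1.11 log units; beyond the scatter), so a large step here is plausible. Compound 1, with the same 4-methoxyphenyl, gives a measurable 13500 nM. In this assay, a lower number is therefore expected for compound 4, although it may also stay at the limit. The estimated change is an at least 2.8-fold lower number from compound 3 to compound 4 (0.45 log units; beyond the scatter). Compound 4 is estimated at 35000 nM, with an expected range of 8000 nM to 100000 nM.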

Compound 4, half-maximal inhibitory concentration: 35900 nM
Compound 4: middle estimate off by 1.0-fold (0.01 log units), on the low side; the measured number falls inside the stated range.
By their numbers in this assay, from the lowest: compounds 2 and 1 (each within the scatter of the next); then compound 4. At a limit, above all of these: compound 3.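

In this assay, 4-methoxyphenyl brings the series back from a limit to a measurable number, with an at least 2.7-fold lower number from compound 3 to compound 4 (0.44 log units; beyond the scatter), and the size of that step is only a bound: the limit of > 100000 nM in this assay, at which 1 of the 4 values shown sits.

Against the plain phenyl, methoxy on this aromatic carbon still gives a 4.7-fold higher number from compound 2 to compound 4 (0.67 log units; beyond the scatter), so the gain over methyl does not extend to hydrogen. Among these compounds, with 4-methoxyphenyl held constant, trifluoromethyl in place of hydroxyamino on the carbonyl carbon gives a 2.7-fold higher number from compound 1 to compound 4 (0.42 log units; beyond the scatter), a first direct reading of that end of the chain.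

Open, on these data alone, is whether an amine or a chlorine on this aromatic carbon would fall nearer hydrogen or methyl. Also open, as far as these compounds go, is how a longer chain would shift these numbers.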